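A few compounds are considered here, and "the series" means these few. Any claim that something is new, unique, unknown or untested is made for them only; others in the source may bear on it.

Compound 1 `C[C@H]1[C@H](NCc2ccsc2)C[C@H]2C[C@@H]1C2(C)C` gives 50000 nM in an ADME assay on MDCK cells (Canis lupus familiaris) for cytotoxicity, read by microscopy, with a stated time of 48 h; on this read-out lower numbers stand for higher toxicity in this test and higher numbers for lower toxicity in this test. Compound 2 `C[C@H]1[C@H](NCc2cncnc2)C[C@H]2C[C@@H]1C2(C)C` reaches only the limit of the test, > 100000 nM, in this assay, as the one limit among the three values (the limit of > 100000 nM in this assay, at which 1 of the 3 values shown sits). Compound 3 `C[C@H]1[C@H](NCc2sccc2Br)C[C@H]2C[C@@H]1C2(C)C` gives 50000 nM in this assay and so stands level with compound 1 at the digits shown, within the scatter; its step of no change at the digits printed from compound 1 to compound 3 (within the scatter) shows that exchanging thiophen-3-yl for 3-bromothiophen-2-yl left the read-out untouched. The step of an at least 2.0-fold higher number from compound 1 to compound 2 (0.30 log units; that floor lies within the scatter) and the step of an at least 2.0-fold lower number from compound 2 to compound 3 (0.30 log units; that floor lies within the scatter) are each no larger than the floor set by the limit of compound 2.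

Compound 4 `C[C@H]1[C@H](NCc2ccc(Br)s2)C[C@H]2C[C@@H]1C2(C)C` differs from compound 3 in one place: 5-bromothiophen-2-yl in place of 3-bromothiophen-2-yl on a saturated chain carbon bound to an amine nitrogen. Going by the values given here, the only step that bears on a change within the thiophene is the one from compound 1 to compound 3, which lay within the scatter, so no step beyond the scatter is expected in this assay in either direction. Compound 4 is therefore expected to give about 50000 nM, between 25000 nM and 100000 nM, an estimated step of no change at the digits printed from compound 3 to compound 4 (within the scatter).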

Compound 4, minimum cytotoxic concentration: 43000 nM
Compound 4: middle estimate off by 1.2-fold (0.07 log units), on the high side; measured number inside the range.
By their numbers in this assay, from the lowest: compounds 4, 1 and 3 (each within the scatter of the next). At a limit, above all of these: compound 2.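

In this assay, the exchange at this saturated chain carbon bound to an amine nitrogen gives a 1.2-fold lower number from compound 3 to compound 4 (0.07 log units; within the scatter), with the same atoms joined differently, and the comparison with the unsubstituted thiophene gives a 1.2-fold lower number from compound 1 to compound 4 (0.07 log units; within the scatter), so neither the place of the bromine on the thiophene nor its presence in 5-bromothiophen-2-yl separates these compounds. Going by these compounds alone, the pyrimidin-5-yl group now stands apart from a thiophene for the first time, with an at least 2.3-fold lower number from compound 2 to compound 4 (0.36 log units; beyond the scatter). That step is only a floor, since the value of compound 2 is a limit: the limit of > 100000 nM in this assay, at which 1 of the 4 values shown sits.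

Going by these compounds, whether an amine, a carboxylic acid or a longer chain on the thiophene would leave the read-out level remains open. Also open, on these data alone, is whether a pyridin-3-yl group on the same carbon would fall with the thiophenes or with compound 2.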